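The source may report more compounds than this note shows. Statements on the series, on what has been measured and on what is new or still open speak of the compounds shown alone.

Two measured compounds frame this account. Compound 2 `Cc1ccc(S(=O)(=O)N2CCC(Br)=CC2CC(C)C)cc1` and compound 1 `CCCCCCCC1C=C(Cl)CCN1S(=O)(=O)c1ccc(C)cc1` were both tested in a functional assay on SW1573 cells (Homo sapiens) for antiproliferative activity, read by sulforhodamine B assay, with a stated time of 48 h; a higher number here means a weaker inhibitor of growth, a lower number a stronger inhibitor of growth. In this assay compound 2 gives 26000 nM, the lower of the two numbers, and compound 1 gives 49000 nM, a value that lies within the usual scatter of the figure for compound 2, so the two cannot be told apart. Compound 3 `CCCCCCCC1C=C(Br)CCN1S(=O)(=O)c1ccc(C)cc1` has not yet been measured. It differs from compound 2 by hexyl in place of isopropyl on a saturated chain carbon bound to a saturated ring carbon. Among the compounds with values here, no measured pair shows this change on its own, so its effect is unknown here. Compound 3 carries the same hexyl chain as compound 1, and because compound 1 gives 49000 nM in this assay, a number in the same region seems plausible for compound 3. The expected step of a 1.5-fold higher number from compound 2 to compound 3 (0.19 log units; within the scatter) is therefore small, close to or within the scatter. Compound 3 is estimated at 40000 nM, with a range from 15000 nM to 110000 nM.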

Compound 3, concentration for 50% growth inhibition: 49000 nM
Compound 3: the middle estimate sits 1.2-fold (0.09 log units) below what was measured; measured number inside the range.
By their numbers in this assay, from the lowest: compounds 2, 1 and 3 (each within the scatter of the next).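

In this assay, hexyl in place of isopropyl on a saturated chain carbon bound to a saturated ring carbon now has a step of its own (a 1.9-fold higher number from compound 2 to compound 3 (0.28 log units; within the scatter)), so the two chains cannot be told apart at this place. Bromo in place of chloro on a double-bonded ring carbon also has its own step (no change at the digits printed from compound 1 to compound 3 (within the scatter)), and with hexyl held constant these two halogens cannot be told apart either. Nothing given here accounts for either result.

Going by these compounds, it remains open whether a chain longer than hexyl, or an amine or a carboxylic acid carried on the chain, would give a number beyond the scatter of these three compounds. Iodo or hydrogen in place of the halogen also remains untested among the compounds shown.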